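Swapping the ketone heterocycle in a fatty-acid amide hydrolase series

This account rests on a few compounds, and the source may have more. Where it says the series, first, only, none or still open, it means among the compounds named here.

Compound 1 `CCCCCCCC/C=C\CCCCCCC(=O)c1nnn(C)n1`: 65 nM in an assay on isolated protein for inhibition of Fatty-acid amide hydrolase 1 (Homo sapiens); a lower number here means a stronger inhibitor, a higher number a weaker inhibitor
Compound 2 `CCCCCCCC/C=C\CCCCCCC(=O)c1nc2ccccc2o1`: 370 nM

Within the data shown here, compound 2 gives the highest number of the two in this assay; the only other value is the one for compound 1, and the step of a 5.7-fold higher number from compound 1 to compound 2 (0.76 log units; beyond the scatter) shows how far apart they lie. Compound 3 `CCCCCCCC/C=C\CCCCCCC(=O)c1cccnn1` has pyridazin-3-yl in place of 1,3-benzoxazol-2-yl on a carbonyl carbon. Among the measured compounds shown here, only that one step exchanges the heterocycle on the carbonyl carbon and so bears on this change, and it was modest. A step of about that size, in either direction, is therefore expected for compound 3, estimated at 200 nM (range 40 nM to 1000 nM), meaning a 1.9-fold lower number from compound 2 to compound 3 (0.27 log units; within the scatter).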

Compound 3, inhibition constant: 130 nM
Compound 3: the middle estimate sits 1.5-fold (0.19 log units) above what was measured, and the stated range covers the measured number.
By their numbers in this assay, from the lowest: compounds 1 and 3 (each within the scatter of the next); then compound 2.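

On the carbonyl carbon, the single ring of pyridazin-3-yl gives a stronger inhibitor than the fused rings of 1,3-benzoxazol-2-yl in this assay (a 2.8-fold lower number from compound 2 to compound 3 (0.45 log units; beyond the scatter)). Replacing 2-methyl-2H-tetrazol-5-yl with pyridazin-3-yl leaves the number within the usual scatter (a 2.0-fold higher number from compound 1 to compound 3 (0.30 log units; within the scatter)), so those two groups cannot be told apart here. Nothing available explains these differences.

As far as these compounds go, whether a plain phenyl ring or a pyridin-2-yl ring would serve as well remains open. So does whether pyridazin-3-yl keeps its place on a shorter chain.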